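Compound 3 to compound 4: butyl replaced by 4-bromophenyl

The source may hold more compounds than are shown below. What is called first, only, known or untested is meant among the compounds shown, and "the series" means these compounds.

In a functional assay on HeLa cells (Homo sapiens) for inhibition, read by sulforhodamine B assay, with a stated time of 48 h (on this read-out higher numbers stand for weaker inhibition of growth and lower numbers for stronger inhibition of growth), compound 1 `COC(=[Se])Nc1ccc2c(C)cc(=O)oc2c1` gives 78000 nM. Compound 2 `CCOC(=[Se])Nc1ccc2c(C)cc(=O)oc2c1` gives > 100000 nM, which is a limit of the assay and not a number. Compound 3 `CCCCNC(=[Se])Nc1ccc2c(C)cc(=O)oc2c1` gives 5200 nM, the lowest of the two numbers in the series.

The next compound is compound 4 `Cc1cc(=O)oc2cc(NC(=[Se])Nc3ccc(Br)cc3)ccc12`, with the change (4-bromophenyl in place of butyl on an amine nitrogen). In words, 4-bromophenyl stands in place of butyl on an amine nitrogen.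

Among the compounds with values here, no measured step changes the group on that nitrogen, so the evidence is indirect. Butylamino in place of methoxy gave a 15-fold lower number from compound 1 to compound 3 (1.18 log units; beyond the scatter), and butylamino in place of ethoxy gave an at least 19-fold lower number from compound 2 to compound 3 (1.28 log units; beyond the scatter). Methyl in place of hydrogen on the oxygen-bound chain gave only an at least 1.2-fold higher number from compound 1 to compound 2 (0.10 log units; that floor lies within the scatter). Compound 4 keeps the amine nitrogen that came with the large step of a 15-fold lower number from compound 1 to compound 3 (1.18 log units; beyond the scatter), so a value closer to that of compound 3 than to that of compound 1 is expected. The size of the effect of the ring itself remains unmeasured, and only a slight lean towards a lower number is assumed.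

The estimate is a step of a 1.5-fold lower number from compound 3 to compound 4 (0.17 log units; within the scatter), which is expected to stay within the scatter. For compound 4 the estimated value is 3500 nM, with an expected range from 700 nM to 15000 nM.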

Compound 4, concentration for 50% growth inhibition: 2200 nM
Estimate against measurement, compound 4: 1.6-fold (0.20 log units) above; measured number inside the range.
By their numbers in this assay, from the lowest: compound 4; then compound 3; then compound 1. At a limit, above all of these: compound 2.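

In this assay, within the data shown here, the exchange of butyl for 4-bromophenyl on the amine nitrogen gives a 2.4-fold lower number from compound 3 to compound 4 (0.37 log units; beyond the scatter) and is the first step that alters the group on that nitrogen while the nitrogen itself stays in place. The earlier steps shown here only replaced methoxy or ethoxy with butylamino, so they could not show whether the group on the nitrogen matters; this one shows that it does, and that one six-membered aromatic ring of carbon only, bearing bromine, is tolerated here in place of an open chain with a modest gain. That gain is modest beside the large step that came with butylamino in place of methoxy (a 15-fold lower number from compound 1 to compound 3 (1.18 log units; beyond the scatter)) and adds to it rather than reversing it.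

From the compounds shown here alone, whether the ring or the bromine carries the step stays open, as does the outcome with a plain phenyl, a 4-chlorophenyl, a benzyl or a longer chain on that nitrogen. No measurement shown here bears on the reason for the step.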